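The source may report more compounds than this note shows. Statements on the series, on what has been measured and on what is new or still open speak of the compounds shown alone.

Measured so far in an ADME assay on microsomes from liver (Mus musculus) for metabolic stability, read by LC-MS, with NADPH named in the record, with a stated time of 60 min, tested at 1 uM, in the absence of a further agent; on this read-out higher numbers stand for a more stable compound and lower numbers for a less stable compound:
Compound 1 `COc1ccc(-c2c(C)nc3c(N4CC[C@@H](NC(=O)c5ccccc5)C4)cc(C)nn23)cc1OC`: > 95%, a limit
Compound 2 `COc1ccc(-c2c(C)nc3c(N4CC[C@@H](NC(=O)Oc5cccc(C)c5)C4)cc(C)nn23)cc1OC`: > 95%, a limit

Compound 2 has no exact number on this read-out, and it shares its position with compound 1: the limit of > 95% in this assay, at which 2 of the 2 values shown sit. Compound 3 `COc1ccc(-c2c(C)nc3c(N4CC[C@@H](NS(=O)(=O)C(C)C)C4)cc(C)nn23)cc1OC` carries isopropylsulfonyl in place of (3-methylphenoxy)carbonyl on an amine nitrogen.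

Among the measured compounds shown here, the only measured step is a step that the two limits leave unreadable from compound 1 to compound 2. It changes the group on the carbonyl carbon and gives no size to carry over. For the measured compounds named here, no measured compound carries isopropylsulfonyl, so the data offer no direct precedent for this change.

The expectation therefore rests on compound 2, which reads > 95%, a limit. In this assay, no step beyond the scatter is expected, although a drop cannot be excluded. The expected step is a number at least 2 percentage points lower from compound 2 to compound 3 (that floor lies within the scatter). For compound 3 the estimated value is 93%, with an expected range from 75% to 100%.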

Compound 3, percent of the compound remaining: > 95%
Compound 3 gave a limit, no number; the forecaster's own chance of this, stated with the estimate: 50%; at least 2 percentage points between middle value and limit.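

No new step can be read among compound 1, compound 2 and compound 3 in this assay, where each result is a limit and not a number: the limit of > 95% in this assay, at which 3 of the 3 values shown sit. The compounds shown leave open whether benzoyl, (3-methylphenoxy)carbonyl and isopropylsulfonyl differ at all in percent of the compound remaining, and which change on the amine nitrogen would give a value off the limit.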